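Swapping isopentyl for 1-methoxy-1-methylethyl in compound 3

The source may report more compounds than this note shows. Statements on the series, on what has been measured and on what is new or still open speak of the compounds shown alone.

In an ADME assay on liver for metabolic stability, with Liver microsome (Homo sapiens) as the target, read by LC-MS, using microsomes (a higher number here means faster removal of the compound, a lower number slower removal), compound 1 (`CC(C)(C)C[C@@H](O)C(=O)N1N=CC[C@H]1C(=O)NCc1cc(Cl)ccc1-n1cnnn1`) gives 22 mL.min-1.g-1 and compound 3 (`CC(C)CC[C@@H](O)C(=O)N1N=CC[C@H]1C(=O)NCc1cc(Cl)ccc1-n1cnnn1`) gives 47 mL.min-1.g-1 as the highest number here. Compound 2 (`O=C(NCc1cc(Cl)ccc1-n1cnnn1)[C@@H]1CC=NN1C(=O)[C@H](O)Cc1ccccc1`) reads < 12 mL.min-1.g-1 which is a limit of the assay and not a number. Compound 4 (`COC(C)(C)[C@@H](O)C(=O)N1N=CC[C@H]1C(=O)NCc1cc(Cl)ccc1-n1cnnn1`) carries 1-methoxy-1-methylethyl in place of isopentyl on a saturated chain carbon bound to a carbonyl carbon and an oxygen on a saturated carbon. Among the compounds with values here, no measured step makes this exact swap, but other side-chain swaps gave a 2.1-fold higher number from compound 1 to compound 3 (0.33 log units; beyond the scatter) and an at least 3.9-fold higher number from compound 2 to compound 3 (0.59 log units; beyond the scatter) so a lower number than that of compound 3 is expected. The estimated step is a 2.4-fold lower number from compound 3 to compound 4 (0.37 log units; beyond the scatter) in size, much like the first of those two. For compound 4 the expected value is 20 mL.min-1.g-1 (range 10 mL.min-1.g-1 to 42 mL.min-1.g-1).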

Compound 4, intrinsic clearance in microsomes: < 12 mL.min-1.g-1
Compound 4: no number, only a limit; the forecaster's own chance of this, stated with the estimate: 25%; middle value at least 1.6-fold (0.22 log units) away from the limit.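

In this assay, 1-methoxy-1-methylethyl at this chain carbon brings an at least 3.9-fold lower number from compound 3 to compound 4 (0.59 log units; beyond the scatter), so an ether oxygen and a branched carbon can replace isopentyl with a clear drop in the number. The other readable step is an at least 1.8-fold lower number from compound 1 to compound 4 (0.26 log units; that floor lies within the scatter), which alone settles little. The step linking the two limit compounds cannot be read, and the readable steps give only minimum sizes: the limit of < 12 mL.min-1.g-1 in this assay, at which 2 of the 4 values shown sit.

Going by these compounds, it remains open whether the oxygen or the branching goes with the lower number. An unbranched methoxyethyl chain at this carbon would separate the two.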